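The source may report more compounds than this note shows. Statements on the series, on what has been measured and on what is new or still open speak of the compounds shown alone.

Compound 1, `Cc1cn([C@@H]2CC[C@H](CO)O2)c(=O)nc1N`, and compound 2, `O=c1nc(NO)ccn1[C@@H]1C=C[C@H](CO)O1`, are the two compounds for which numbers exist. In an ADME assay on HepG2 cells (Homo sapiens) for cytotoxicity, read by MTT assay, with a stated time of 3 days (on this read-out lower numbers stand for higher toxicity in this test and higher numbers for lower toxicity in this test), compound 1 gives 1550000 nM, and in this assay compound 2 gives 2500000 nM; the gap between these two numbers lies within the usual scatter, so neither can be set apart from the other on this test. Compound 3, `Cc1cn([C@@H]2C[C@@H](F)[C@H](CO)O2)c(=O)nc1N`, has not yet been measured. It differs from compound 1 by fluoro in place of hydrogen on a saturated ring carbon. Among the measured compounds shown here, no measured pair shows the effect of such a change on this read-out, so the expected step rests only on the values of compound 1 and compound 2, which sit close together. The step from compound 1 to compound 3 is expected to be small, a 1.6-fold lower number from compound 1 to compound 3 (0.19 log units; within the scatter), possibly toward somewhat higher toxicity but not clearly beyond the scatter. Compound 3 is therefore estimated at 1000000 nM, within a range from 300000 nM to 3000000 nM.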

Compound 3, half-maximal cytotoxic concentration: 1800000 nM
The estimate for compound 3 lay 1.8-fold (0.26 log units) below the measured number; low and high end bracket the measured number.
By their numbers in this assay, from the lowest: compounds 1, 3 and 2 (each within the scatter of the next).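

In this assay, fluoro in place of hydrogen on a saturated ring carbon gives a 1.2-fold higher number from compound 1 to compound 3 (0.06 log units; within the scatter) and so does not set the two compounds apart on this test. Among the compounds shown here, this is the first measured step at this position, which lies next to the ring atom that bears a hydroxymethyl group, and it shows that one fluorine atom here leaves the half-maximal cytotoxic concentration within the scatter of the hydrogen compound. Nothing in the available data gives a reason for this result.

This single pair leaves open whether an amine, a hydroxyl group or an azide group on the same ring carbon would also stay within the scatter. It also leaves open whether fluoro would behave in the same way on a saturated ring carbon elsewhere in the ring.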